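The source may hold more compounds than are shown below. What is called first, only, known or untested is meant among the compounds shown, and "the series" means these compounds.

Working notes on the series.

Compound 3 `FC(F)(F)c1ccc(CSc2nc(Nc3ccc(C(F)(F)F)cc3)c3ccccc3n2)cc1` is one of three analogues sharing a common core, which in a functional assay on PC-3 cells (Homo sapiens) for cytotoxicity, read by MTT assay, with a stated time of 72 h (on this read-out lower numbers stand for stronger inhibition and higher numbers for weaker inhibition), gives 7880 nM. Compound 1 `Fc1ccc(Nc2nc(SCc3ccc(C(F)(F)F)cc3)nc3ccccc23)cc1` in this assay gives 7070 nM, and compound 2 `O=[N+]([O-])c1ccc(Nc2nc(SCc3ccc(C(F)(F)F)cc3)nc3ccccc23)cc1` gives 7900 nM. Among the three numbers compound 3 sits second highest, but the differences are small: a 1.1-fold higher number from compound 1 to compound 3 (0.05 log units; within the scatter), a 1.0-fold lower number from compound 2 to compound 3 (0.00 log units; within the scatter), and a 1.1-fold higher number from compound 1 to compound 2 (0.05 log units; within the scatter). All three are within the scatter, so no ordering can be drawn from them.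

Compound 4 `CCOc1ccc(Nc2nc(SCc3ccc(C(F)(F)F)cc3)nc3ccccc23)cc1` is not yet measured. The change from compound 3 is ethoxy in place of trifluoromethyl on an aromatic carbon. Among the measured compounds shown here, none of the measured steps involves an ethoxy group; they only show that swapping fluoro, nitro or trifluoromethyl at this position leaves the read-out unchanged within the scatter. For the measured compounds named here, there is no measured precedent for the ethoxy substituent, so the expectation rests on the flat behaviour of the three measured analogues at this position, with the caution that an oxygen-bearing group has not been sampled.

Compound 4 is therefore expected to stay close to compound 3, with an estimated step of a 1.0-fold higher number from compound 3 to compound 4 (0.00 log units; within the scatter). The estimate for compound 4 in this assay is 7900 nM, with a range from 3000 nM to 20000 nM.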

Compound 4, half-maximal inhibitory concentration: 32100 nM
The estimate for compound 4 lay 4.1-fold (0.61 log units) below the measured number; the whole stated range lies below it.
By their numbers in this assay, from the lowest: compounds 1, 3 and 2 (each within the scatter of the next); then compound 4.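

In this assay, this position, on an aromatic carbon para to a large group, is not indifferent to every substituent: ethoxy gives a 4.1-fold higher number from compound 3 to compound 4 (0.61 log units; beyond the scatter), with matching steps of a 4.1-fold higher number from compound 2 to compound 4 (0.61 log units; beyond the scatter) and a 4.5-fold higher number from compound 1 to compound 4 (0.66 log units; beyond the scatter), all modest but beyond the scatter. Fluoro, nitro and trifluoromethyl remain within the scatter of one another, so the flat behaviour of the earlier compounds holds for those three groups only, and compound 4 is the weakest of the four on this read-out. Nothing available explains why the ethoxy change departs from the other three substituents.

The compounds shown leave open whether the step follows the oxygen attached to the ring or the ethyl chain that it carries, a question that methoxy, hydroxyl, a plain ethyl group or a longer propoxy chain at the same position would help to separate. They also leave open how an amine at this position would read, and whether the ethoxy step would persist with a change elsewhere on the shared core.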